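Aryl variation on the nitrogen-bound methylene: compound 3

This account rests on a few compounds, and the source may have more. Where it says the series, first, only, none or still open, it means among the compounds named here.

Measured so far in an assay on isolated protein for inhibition of DNA topoisomerase 1 (Homo sapiens), with a stated time of 15 min; on this read-out higher numbers stand for weaker inhibition and lower numbers for stronger inhibition:
- compound 1 `CNC(=O)c1cn(Cc2ccc(-c3ccccc3)cc2)c2c(OC)c(N3CC[C@@H](CN)C3)c(F)cc2c1=O`: 82100 nM
- compound 2 `COc1c(N2CC[C@@H](CN)C2)c(F)cc2c(=O)c(C(=O)O)cn(Cc3ccc(-n4cccn4)cc3)c12`: > 200000 nM

Compound 1 returns a numerical value in this assay. Compound 2 returns only a limit of this assay and no number, (the limit of > 200000 nM in this assay, at which 1 of the 2 values shown sits), so it stands at the weak end of the numbers shown. The two compounds differ in more than one place, so their values are noted side by side without a computed step.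

Compound 3 `COc1c(N2CC[C@@H](CN)C2)c(F)cc2c(=O)c(C(=O)O)cn(Cc3ccc4ccccc4c3)c12` is the next entry, differing from compound 2 by naphthalen-2-yl in place of 4-(1H-pyrazol-1-yl)phenyl on a saturated chain carbon bound to an aromatic nitrogen. Among the compounds with values here, no measured step covers this change. The all-carbon naphthalen-2-yl recalls the all-carbon aryl of compound 1, which gave a number rather than a limit, but compound 1 also carries a different acyl group, so no direction is secured. A small shift toward stronger inhibition, possibly within the scatter, is expected. Compound 3 is estimated at 120000 nM (range 40000 nM to 400000 nM), corresponding to an expected step of an at least 1.6-fold lower number from compound 2 to compound 3 (0.22 log units; that floor lies within the scatter).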

Compound 3, half-maximal inhibitory concentration: 43700 nM
Compound 3: middle estimate off by 2.7-fold (0.44 log units), on the high side; the measured number falls inside the stated range.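

On a saturated chain carbon bound to an aromatic nitrogen, naphthalen-2-yl in place of 4-(1H-pyrazol-1-yl)phenyl gives an at least 4.5-fold lower number from compound 2 to compound 3 (0.66 log units; beyond the scatter) in this assay, so this aryl change alone moves the read-out beyond the scatter. Compound 3 also returns a number with the carboxylic acid in place, so the acid does not by itself hold a compound at the assay's limit. Going by these compounds, compound 2 has only a limit, so this step is a floor and its full size is unknown: the limit of > 200000 nM in this assay, at which 1 of the 3 values shown sits.

On these data alone, whether the shift tracks the loss of the pyrazole or the presence of the fused carbon ring stays open, and a plain phenyl on the same methylene would help separate the two. Compound 1 differs from compound 3 in more than one place, so the N-methyl amide and the carboxylic acid remain uncompared on a matched aryl group.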